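This account rests on a few compounds, and the source may have more. Where it says the series, first, only, none or still open, it means among the compounds named here.

Measured so far in a functional assay on MCF7 cells (Homo sapiens) for antiproliferative activity, read by sulforhodamine B assay, with a stated time of 48 h; on this read-out higher numbers stand for weaker inhibition and lower numbers for stronger inhibition:
compound 1, `COc1cc(C=C(C(=O)/C=C/c2cccc(OC)c2OC)C(=O)/C=C/c2cccc(OC)c2OC)cc(OC)c1O`: 460 nM
compound 2, `COc1ccc(C=C(C(=O)/C=C/c2cccc(OC)c2OC)C(=O)/C=C/c2cccc(OC)c2OC)cc1O`: 310 nM
compound 3, `COc1ccc(OC)c(/C=C/C(=O)C(=Cc2cc(OC)c(O)c(OC)c2)C(=O)/C=C/c2cc(OC)ccc2OC)c1`: 430 nM

Compound 4, `COc1ccc(OC)c(/C=C/C(=O)C(=Cc2ccc(OC)c(O)c2)C(=O)/C=C/c2cc(OC)ccc2OC)c1`, has not yet been measured in this assay. It shares its core with compound 3; the difference between that core and the core of compound 1 is not broken down here. From compound 1 to compound 2 the change is 3-hydroxy-4-methoxyphenyl in place of 4-hydroxy-3,5-dimethoxyphenyl on a double-bonded chain carbon bound to a double-bonded chain carbon, and it gave a 1.5-fold lower number from compound 1 to compound 2 (0.17 log units; within the scatter). The change from compound 3 to compound 4 is 3-hydroxy-4-methoxyphenyl in place of 4-hydroxy-3,5-dimethoxyphenyl on a double-bonded chain carbon bound to a double-bonded chain carbon, made at the same place, so it is the same change. In this assay compound 4 is therefore expected to show a step of about a 1.5-fold lower number from compound 3 to compound 4 (0.17 log units; within the scatter), resting on compound 1 to compound 2 giving a 1.5-fold lower number from compound 1 to compound 2 (0.17 log units; within the scatter). Compound 4 is estimated at 290 nM, likely between 150 nM and 560 nM.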

Compound 4, half-maximal inhibitory concentration: 990 nM
Compound 4: the middle estimate sits 3.4-fold (0.53 log units) below what was measured; measured number above the stated range.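

In this assay, putting 3-hydroxy-4-methoxyphenyl in place of 4-hydroxy-3,5-dimethoxyphenyl gave a 2.3-fold higher number from compound 3 to compound 4 (0.36 log units; beyond the scatter), a modest step. Set beside the earlier step, the same change did not carry over from one core to the other: the same change on two cores in this assay, a 1.5-fold lower number (0.17 log units; within the scatter) from compound 1 to compound 2 and a 2.3-fold higher number (0.36 log units; beyond the scatter) from compound 3 to compound 4, 3.4-fold (0.53 log units) apart, beyond the scatter of two such steps. This shows that the result of this change cannot be assumed to transfer between these two cores, but it does not show which feature of the cores accounts for the gap, and two pairs give no rule for any other core.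

The compounds shown leave open how a phenyl group bearing an amine or a carboxylic acid would behave at this place on either core. Also open, as far as these compounds go, is whether the two cores would part in the same way for other changes.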